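The compounds below may be only part of what the source reports. "The series", "measured", "known", "first", "only" and "open" are said of these compounds alone.

Compound 1 `CC(CSc1ccc(F)cc1)C(=O)Nc1ccc(C#N)c(C(F)(F)F)c1` and compound 2 `CC(CSc1ccc(F)cc1)C(=O)Nc1ccc([N+](=O)[O-])c(C(F)(F)F)c1` share one core and differ in a single place. In a functional assay on LNCaP cells (Homo sapiens) for antiproliferative activity, read by MTT assay, with a stated time of 96 h (a higher number here means a weaker inhibitor, a lower number a stronger inhibitor), compound 1 gives 8690 nM, while compound 2 gives 27200 nM. The change between them, (nitro in place of cyano on an aromatic carbon), made a 3.1-fold higher number from compound 1 to compound 2 (0.50 log units; beyond the scatter). Compound 3 `CC(CS(=O)(=O)c1cc(C(F)(F)F)cc(C(F)(F)F)c1)C(=O)Nc1ccc(C#N)cc1C(F)(F)F` rests on another core; how the cores of compound 1 and compound 3 differ is not broken down here. In this assay compound 3 gives 9560 nM, a value close to that of compound 1 and separated from that of compound 2.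

Compound 4 `CC(CS(=O)(=O)c1cc(C(F)(F)F)cc(C(F)(F)F)c1)C(=O)Nc1ccc([N+](=O)[O-])cc1C(F)(F)F` has not yet been measured. Among the measured compounds shown here, it differs from compound 3 by nitro in place of cyano on an aromatic carbon, the same kind of change as the one from compound 1 to compound 2, but not the same change: in compound 1 the cyano sits ortho to a trifluoromethyl group, whereas in compound 3 it sits meta to a trifluoromethyl group, and in both it is para to a large group. Compound 4 is expected to take a step of a 2.6-fold higher number from compound 3 to compound 4 (0.42 log units; beyond the scatter), because the same kind of change gave a 3.1-fold higher number from compound 1 to compound 2 (0.50 log units; beyond the scatter). The different surroundings of the place leave room for a smaller or a larger shift. Compound 4 is therefore estimated at 25000 nM in this assay. For compound 4 the estimated range runs from 10000 nM to 60000 nM.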

Compound 4, half-maximal inhibitory concentration: 3080 nM
Estimate against measurement, compound 4: 8.1-fold (0.91 log units) above, and the stated range ends above it.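

In this assay, nitro in place of cyano on an aromatic carbon gave a 3.1-fold lower number from compound 3 to compound 4 (0.49 log units; beyond the scatter), which runs in the opposite direction to the step on the core of compound 1, and the two steps differ by more than the scatter: the same change on two cores in this assay, a 3.1-fold higher number (0.50 log units; beyond the scatter) from compound 1 to compound 2 and a 3.1-fold lower number (0.49 log units; beyond the scatter) from compound 3 to compound 4, 9.7-fold (0.99 log units) apart, beyond the scatter of two such steps. This shows that, among these two pairs, neither the direction nor the size of the step carried from one core to the other, so the outcome on the core of compound 1 gave no reliable guide to the outcome on the core of compound 3. It does not show which of the differences between the two cores goes with the reversal, nor which direction would prevail on any further core, and it gives no cause for the reversal.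

The compounds shown leave open how the same change would behave on a core that differs from the core of compound 3 in one place only, which is the comparison that could tie the reversal to a single feature. They also leave open how an amine or a carboxylic acid on that same aromatic carbon would compare with cyano and nitro in this assay.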